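Chloro to bromo on the shared core

A few compounds are considered here, and "the series" means these few. Any claim that something is new, unique, unknown or untested is made for them only; others in the source may bear on it.

compound 1 `O=C(Cc1cccnc1)c1cc2ccccc2[nH]1`: 13%
compound 2 `O=C(Cc1cccnc1)c1cc2cc(Cl)ccc2[nH]1`: 24%

In an in vitro assay on P815B cells for inhibition of Indoleamine 2,3-dioxygenase 1 (Mus musculus), tested at 20 uM (a lower number here means less inhibition, a higher number more inhibition at the concentration tested (going by the name of the read-out)), compound 2 stands highest of the two numbers, with compound 1 as its nearest neighbour. Among the measured compounds shown here, the only measured step, a number 11 percentage points higher from compound 1 to compound 2 (beyond the scatter), put chloro in place of hydrogen. Compound 3 `O=C(Cc1cccnc1)c1cc2cc(Br)ccc2[nH]1` differs from compound 2 by bromo in place of chloro on an aromatic carbon. For the measured compounds named here, no measured step exchanges one halogen for another, so that one step is only a loose guide. Compound 3 is therefore expected to stay near compound 2, with a step of about a number 4 percentage points higher from compound 2 to compound 3 (within the scatter) and none beyond the scatter. The estimate for compound 3 is 28%, in the range 12% to 44%.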

Compound 3, a percentage reported as inhibition, at one concentration (the size of the read-out at that concentration, not a potency): "not active" (no number reported)
For compound 3 the study gives words and no number; no gap can be computed for the estimate.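

Among the compounds shown here, compound 3 is reported in this assay only as not active, without a number, so no step from compound 2 to compound 3 can be read. The compounds shown leave open how large any difference between chloro and bromo is. Nothing shown here bears on this result.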